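Methoxy on the shared core: a limit-bound cytotoxicity step

The compounds below may be only part of what the source reports. "The series", "measured", "known", "first", "only" and "open" are said of these compounds alone.

Compound 1 `COc1ccc2c(=O)cc(C)[nH]c2c1` gives > 52800 nM (a limit)
Compound 2 `Cc1[nH]c2ccccc2c(=O)c1Cc1ccccc1` gives > 40100 nM (a limit)
Compound 3 `COc1ccc2[nH]c(C)c(Cc3ccccc3)c(=O)c2c1` gives > 23700 nM (a limit)

All three results in an ADME assay on J774 cells (Mus musculus) for cytotoxicity (on this read-out higher numbers stand for an effect only at larger amounts of compound and lower numbers for an effect already at smaller amounts), are limits and not numbers. Compound 2 also has only a limit, > 40100 nM. Compound 4 `COc1ccc2c(=O)c(Cc3ccccc3)c(C)[nH]c2c1` differs from compound 2 by one change, methoxy in place of hydrogen on an aromatic carbon. Among the measured compounds shown here, the one measured step with this kind of swap, on a different aromatic carbon, is a step that the two limits leave unreadable from compound 2 to compound 3. That step offers no size and no direction, so no step beyond the scatter is expected in this assay. The estimate means an at least 1.3-fold lower number from compound 2 to compound 4 (0.12 log units; that floor lies within the scatter), an expected step. Compound 4 is expected at about 30000 nM, within an estimated range of 15000 nM to 60000 nM, and will most likely be reported as a limit again.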

Compound 4, half-maximal effective concentration: > 35800 nM
Compound 4 gave a limit, no number (the forecaster's own chance of this, stated with the estimate: 85%); middle value at least 1.1-fold (0.07 log units) away from the limit.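

Compound 4, like compound 1 and compound 2, is reported only as a limit, so neither step to compound 4 can be read. The compounds shown leave open whether methoxy or benzyl shifts the result in this assay at all.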